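From Hydroxy to Propanoylamino on a Shared Core

The source may hold more compounds than are shown below. What is called first, only, known or untested is meant among the compounds shown, and "the series" means these compounds.

Of the compounds shown here, two sharing one core have been tested in an ADME assay on BHK cells (Mesocricetus auratus) for cytotoxicity, read by MTT assay, with a stated time of 96 h; on this read-out lower numbers stand for higher toxicity in this test and higher numbers for lower toxicity in this test. Compound 1 `COc1ccc(-c2nc3cc(C(F)(F)F)ccc3[nH]2)c(OC)c1OC` carries three methoxy groups, and in this assay compound 1 gives 32000 nM. Compound 2 `Oc1ccc(-c2nc3cc(C(F)(F)F)ccc3[nH]2)cc1` carries a single hydroxy group in their place. For compound 2 this assay reports only a limit, > 100000 nM, and not a number. That limit is the one described by the limit of > 100000 nM in this assay, at which 1 of the 2 values shown sits, so compound 2 stands at the low-toxicity end of what this test can resolve. Compound 3 `CCC(=O)Nc1ccc(-c2nc3cc(C(F)(F)F)ccc3[nH]2)cc1` has not yet been measured. It differs from compound 2 in one place: propanoylamino in place of hydroxy on an aromatic carbon. Within the data shown here, no measured pair with a change of this kind is available. For compound 3 the expected step is an at least 1.2-fold lower number from compound 2 to compound 3 (0.09 log units; that floor lies within the scatter), little if anything beyond the usual scatter. Compound 3 is therefore estimated at 80000 nM, with a range from 25000 nM to 250000 nM.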

Compound 3, half-maximal cytotoxic concentration: 100000 nM
Compound 3: middle estimate off by 1.3-fold (0.10 log units), on the low side, within the range that was stated.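

In this assay, putting propanoylamino in place of hydroxy, para to a large group, gives a number no higher from compound 2 to compound 3 (the limit leaves the size open). For compound 2 the assay gives only a limit and not a number, and the size of the step stays open because of it: the limit of > 100000 nM in this assay, at which 1 of the 3 values shown sits.

What is new is that this position can carry a group of 5 heavy atoms instead of 1, and compound 3 still gives a number high on this scale, 100000 nM, which in this test stands for low toxicity.

The compounds shown do not tell how an amine or a carboxylic acid at this position would read in this assay. They also leave open whether a longer chain than propanoylamino would keep the number this high.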